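The compounds below may be only part of what the source reports. "The series", "measured", "known", "first", "only" and "open" are said of these compounds alone.

Measured compounds:
- compound 1, `CC(/C=N/Nc1ccc([N+](=O)[O-])cc1)=N\NC(=O)c1ccc(O)cc1`: 1510 nM
- compound 2, `CC(/C=N/Nc1ccc([N+](=O)[O-])cc1)=N\NC(=O)c1ccccc1N`: 4900 nM
- compound 3, `CC(/C=N/N(C)c1ccc([N+](=O)[O-])cc1)=N\NC(=O)c1cc([N+](=O)[O-])cc([N+](=O)[O-])c1`: 1110 nM

In a functional assay on cells (Splenocyte, Mus musculus, strain BALB/c) for inhibition, read by scintillation counting and thymidine incorporation, with a stated time of 72 h (on this read-out higher numbers stand for weaker inhibition and lower numbers for stronger inhibition), compound 1 stands second highest of the three numbers. Compound 3 lies within the scatter of it, so the two cannot be ordered. Compound 2 is set apart by a 3.2-fold higher number from compound 1 to compound 2 (0.51 log units; beyond the scatter), a modest step. Compound 4, `CC(/C=N/Nc1ccc([N+](=O)[O-])cc1)=N\NC(=O)c1ccc([N+](=O)[O-])cc1`, differs from compound 1 by nitro in place of hydroxy on an aromatic carbon. Among the measured compounds shown here, only the step from compound 1 to compound 2 bears on this, and it changes a different group; no measured pair exchanges hydroxy for nitro. The expectation for this assay is therefore a step no larger than the scatter, direction uncertain. Compound 4 is estimated at 1800 nM (range 700 nM to 4600 nM), which means an expected 1.2-fold higher number from compound 1 to compound 4 (0.08 log units; within the scatter).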

Compound 4, half-maximal inhibitory concentration: 980 nM
Compound 4: the middle estimate sits 1.8-fold (0.26 log units) above what was measured; low and high end bracket the measured number.
By their numbers in this assay, from the lowest: compounds 4, 3 and 1 (each within the scatter of the next); then compound 2.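

In this assay, nitro replaces hydroxy on the aromatic carbon para to a large group with a 1.5-fold lower number from compound 1 to compound 4 (0.19 log units; within the scatter), so this pair shows that the hydrogen-bond donor leaving with hydroxy makes no difference beyond the scatter. The group on the carbonyl carbon still matters, as 4-nitrophenyl in place of 2-aminophenyl gives a 5.0-fold lower number from compound 2 to compound 4 (0.70 log units; beyond the scatter). No evidence on the cause accompanies these numbers.

From the compounds shown here alone, it remains open how an amine or a carboxylic acid would read at that same place, para to a large group. An amine there would also help show whether the gap for 2-aminophenyl follows the group itself or where it sits.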